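Cytotoxicity on Vero cells: azidonucleosides, step to compound 4

The compounds below may be only part of what the source reports. "The series", "measured", "known", "first", "only" and "open" are said of these compounds alone.

Measured compounds, with their cytotoxicity values:
compound 1, `C=CCN(C)c1nc(N)nc2c1ncn2[C@H]1C[C@H](N=[N+]=[N-])[C@@H](CO)O1`: 32000 nM
compound 2, `[N-]=[N+]=N[C@H]1C[C@H](n2cnc3c(N)nc(F)nc32)O[C@@H]1CO`: 34400 nM
compound 3, `CN(C)c1nc(Cl)nc2c1ncn2[C@H]1C[C@H](N=[N+]=[N-])[C@@H](CO)O1`: limit, > 100000 nM

In an ADME assay on Vero cells (Chlorocebus sabaeus) for cytotoxicity, with a stated time of 5 days (a lower number here means a stronger inhibitor, a higher number a weaker inhibitor), compound 1 gives 32000 nM and compound 2 gives 34400 nM; the two sit within the scatter of each other, so neither is told apart from the other. For compound 3 this assay reports only a limit, > 100000 nM, a limit at which (the limit of > 100000 nM in this assay, at which 1 of the 3 values shown sits). Compound 1 thus holds the lowest of the two numbers shown, with compound 2 close by.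

Compound 4, `[N-]=[N+]=N[C@H]1C[C@H](n2cnc3c(NC4CC4)nc(N)nc32)O[C@@H]1CO`, differs from compound 1 in one place: cyclopropylamino in place of allyl(methyl)amino on an aromatic carbon. Within the data shown here, no measured pair with a change of this kind is on hand, so the expected step rests on the narrow spread of compound 1 and compound 2 alone. The step from compound 1 to compound 4 in this assay is expected to be small, a 1.3-fold higher number from compound 1 to compound 4 (0.10 log units; within the scatter), with no clear direction beyond the scatter. For compound 4 the estimate in this assay is 40000 nM, with a range from 15000 nM to 100000 nM.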

Compound 4, half-maximal inhibitory concentration: > 100000 nM
Compound 4: only a limit was reported; the forecaster's own chance of this, stated with the estimate: 35%; middle value at least 2.5-fold (0.39 log units) away from the limit.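

In this assay, cyclopropylamino in place of allyl(methyl)amino on an aromatic carbon gives an at least 3.1-fold higher number from compound 1 to compound 4 (0.49 log units; beyond the scatter), so cytotoxicity responds to a change at this position of the shared core. This is the only step shown at this position, and it moves to the weaker side. The value of compound 4 is a limit, so the step has a lower bound only: the limit of > 100000 nM in this assay, at which 2 of the 4 values shown sit.

Going by these compounds, whether the three-membered ring or the added hydrogen-bond donor carries the step stays open. Also open, on these data alone, is what methylamino or a longer chain such as butylamino would give at this place.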